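A few compounds are considered here, and "the series" means these few. Any claim that something is new, unique, unknown or untested is made for them only; others in the source may bear on it.

Compound 1 `Oc1cccc(-c2cc(-c3ccc(F)cc3)cc(-c3ccccc3O)n2)c1`: > 50000 nM
Compound 2 `Oc1cccc(-c2cc(-c3cccc(F)c3)cc(-c3cccc(O)c3)n2)c1`: 23800 nM

Among the measured compounds shown here, in a functional assay on DU-145 cells (Homo sapiens) for inhibition (a higher number here means a weaker inhibitor, a lower number a stronger inhibitor), compound 2 gives 23800 nM, the only plain number among the two results. Compound 1 gives > 50000 nM, which is a limit of this assay and not a number (the limit of > 50000 nM in this assay, at which 1 of the 2 values shown sits). Compound 3 `Oc1cccc(-c2cc(-c3ccc(F)cc3)cc(-c3cccc(O)c3)n2)c1` differs from compound 2 in one place: 4-fluorophenyl in place of 3-fluorophenyl on an aromatic carbon. For the measured compounds named here, no measured step of this kind is available, so the expected step of a 1.2-fold higher number from compound 2 to compound 3 (0.07 log units; within the scatter) is taken to be small, in no particular direction, and within the scatter. Compound 3 is accordingly estimated at 28000 nM, expected to lie between 9000 nM and 60000 nM.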

Compound 3, half-maximal inhibitory concentration: 7120 nM
Beside the measured number, compound 3's estimate is 3.9-fold (0.59 log units) above it; measured number below the stated range.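

With 4-fluorophenyl in place of 3-fluorophenyl, this assay shows a 3.3-fold lower number from compound 2 to compound 3 (0.52 log units; beyond the scatter), so on the ring opposite the ring nitrogen the place of the fluorine alone changes the result. The place of a hydroxyl on a neighbouring aryl group also counts, with 3-hydroxyphenyl in place of 2-hydroxyphenyl giving an at least 7.0-fold lower number from compound 1 to compound 3 (0.84 log units; beyond the scatter). That step is only a bound, as compound 1 gives a limit of the assay and not a number: the limit of > 50000 nM in this assay, at which 1 of the 3 values shown sits.

On these data alone, whether 4-chlorophenyl or 4-aminophenyl at this position would give a lower number remains open. So does the result for a carboxylic acid on this ring.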